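Allylamino to Butylamino: Inhibition Barely Detectable

This account rests on a few compounds, and the source may have more. Where it says the series, first, only, none or still open, it means among the compounds named here.

Of the compounds shown here, three have been measured in a functional assay for inhibition, read by spectrophotometry, with a stated time of 30 min, tested at 1 uM; a higher number here means more inhibition at the concentration tested (going by the name of the read-out), a lower number less inhibition. Compound 1 `C=CCNC(=C\C(=O)/C=C/c1ccc(O)c(OC)c1)/C=C/c1ccc(O)c(OC)c1` gives 0.1%. Compound 2 `COc1cc(/C=C/C(=O)CC(=O)/C=C/c2ccc(OC(C)=O)c(OC)c2)ccc1OC(C)=O` gives 0% in this assay. Compound 3 `CCC(C)NC(=C\C(=O)/C=C/c1ccc(OC(C)=O)c(OC)c1)/C=C/c1ccc(OC(C)=O)c(OC)c1` gives 0% in this assay. Compound 1 holds the highest of the three numbers, but its distances to compound 2 and to compound 3 both lie within the usual scatter, so the three cannot be told apart; each shows essentially no inhibition at the concentration tested.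

Compound 4 `CCCCNC(=C\C(=O)/C=C/c1ccc(O)c(OC)c1)/C=C/c1ccc(O)c(OC)c1` has not been measured yet. It differs from compound 1 in one place: propyl in place of vinyl on a saturated chain carbon bound to an amine nitrogen. Within the data shown here, no two measured compounds differ in a single place, so there is no measured step to lean on. The expected step is a number 0.9 percentage points higher from compound 1 to compound 4 (within the scatter), none beyond the scatter, because compound 1 already gives 0.1% and compound 2 and compound 3 lie close by. Compound 4 is therefore estimated at 1% in this assay, with a range from 0% to 10%.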

Compound 4, a percentage reported as inhibition, at one concentration (the size of the read-out at that concentration, not a potency): 0.08%
Beside the measured number, compound 4's estimate is 0.9 percentage points above it; low and high end bracket the measured number.
By their numbers in this assay, from the lowest: compounds 2, 3, 4 and 1 (each within the scatter of the next).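

Moving from allylamino to butylamino gives a number 0 percentage points lower from compound 1 to compound 4 (within the scatter) in this assay and provides the first comparison of compounds differing in a single place. On this chain, bound to the amine nitrogen, replacing vinyl with propyl removes the double bond and adds one carbon, yet inhibition remains barely detectable at the concentration tested. Nothing available explains this flat result, and with both compounds so close to zero, the comparison cannot show how much this position matters.

On these data alone, it remains open whether any other group at this position would produce clear inhibition, such as a benzyl group, a chain ending in a carboxylic acid, or a much longer chain. It is also unknown whether compound 1 and compound 4 would separate at a higher concentration.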